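The compounds below may be only part of what the source reports. "The series", "measured", "known", "first", "only" and "open" are said of these compounds alone.

Measured so far:
- compound 1, `Nc1ccccc1NC(=O)c1ccc(Cn2cnc3c(NCc4ccccc4)nc(Cl)nc32)cc1`: 5830 nM
- compound 2, `Nc1ccccc1NC(=O)c1ccc(COCNc2nc(Nc3ccccc3)c3ncn(C4CCCC4)c3n2)cc1`: 8700 nM
- compound 3, `CCCCn1cnc2c(Nc3cccc(Cl)c3)nc(NCOCc3ccc(C(=O)Nc4ccccc4N)cc3)nc21`: 6820 nM

All three carry the same benzamide bearing the 2-aminophenyl amide, joined through a linker to a substituted purine-type core; they differ in the core substituents and in the linker. In a functional assay on A-375 cells (Homo sapiens) for antiproliferative activity, read by CCK-8 assay, with a stated time of 72 h (a lower number here means a stronger inhibitor, a higher number a weaker inhibitor), compound 1 gives the lowest of the three numbers, but its nearest neighbour compound 3 and its furthest neighbour compound 2 both sit within the scatter of it, so the three cannot be ordered on these data.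

Compound 4, `Nc1ccccc1NC(=O)c1ccc(Cn2cnc3c(Nc4cccc(Cl)c4)nc(Cl)nc32)cc1`, is not yet measured. It differs from compound 1 in one place: 3-chlorophenyl in place of benzyl on a nitrogen on an aromatic ring. For the measured compounds named here, no pair of measured compounds differs in only this one place, so the size of the step is open. Compound 3 carries the (3-chlorophenyl)amino group on a differently substituted core and differently attached linker, and with 6820 nM it sits in the same range as compound 1, which gives no hint of a move beyond the scatter in either direction. For compound 4 in this assay the expected value is 5000 nM, within 2000 nM to 14000 nM. The expected step of a 1.2-fold lower number from compound 1 to compound 4 (0.07 log units; within the scatter) is therefore estimated as none beyond the scatter.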

Compound 4, half-maximal inhibitory concentration: 6080 nM
For compound 4 the middle estimate is 1.2-fold (0.08 log units) below the measured one; the range from low to high includes it.
By their numbers in this assay, from the lowest: compounds 1, 4, 3 and 2 (each within the scatter of the next).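

In this assay the series gains its first comparison that differs in one place: 3-chlorophenyl in place of benzyl on a nitrogen on an aromatic ring gives a 1.0-fold higher number from compound 1 to compound 4 (0.02 log units; within the scatter) and so leaves the two compounds indistinguishable in this read-out. The earlier compounds shown here could not show this, as no two of them differed in one place only; here, on the core of compound 1, benzylamino and (3-chlorophenyl)amino can be exchanged with no change beyond the scatter, although the entering group carries a chlorine and the leaving group does not. No available measurement bears on why this exchange leaves the number within the scatter.

For the compounds shown here, this single step compares only two groups that each carry a six-membered aromatic ring of carbon only, so it remains open whether the position tolerates other kinds of group, such as a morpholine ring, a primary amine or a longer alkyl chain. As far as these compounds go, it also remains open whether the same exchange would behave alike on a core carrying a different linker or a different substituent, as the cores of compound 2 and compound 3 do.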